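The source may report more compounds than this note shows. Statements on the series, on what has been measured and on what is new or still open speak of the compounds shown alone.

Measured so far:
compound 1 `Cn1c(/C=C2\SC(=O)N(CC(=O)Nc3nc(-c4ccccc4)cs3)C2=O)nc2ccccc21` gives 29200 nM;
compound 2 `CCn1c(/C=C2\SC(=O)N(CC(=O)N3CCCC3)C2=O)nc2ccccc21` gives > 50000 nM, which is a limit of the assay and not a number;
compound 3 `CC(C)n1c(/C=C2\SC(=O)N(CC(=O)N3CCCC3)C2=O)nc2ccccc21` gives > 50000 nM, likewise a limit.

In a functional assay on MDA-MB-231 cells (Homo sapiens) for inhibition, read by MTT assay, with a stated time of 48 h (a higher number here means a weaker inhibitor, a lower number a stronger inhibitor), compound 1 is the only one of the three that yields a number; the other two sit at the limit of > 50000 nM in this assay, at which 2 of the 3 values shown sit. The difference between the core of compound 1 and that of compound 2 is not broken down here. Compound 3 differs from compound 2 by methyl in place of hydrogen on a saturated chain carbon bound to an aromatic nitrogen and a saturated chain carbon, and the step that the two limits leave unreadable from compound 2 to compound 3 cannot be read because both ends are limits.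

Compound 4 `CCn1c(/C=C2\SC(=O)N(CC(=O)Nc3nc(-c4ccccc4)cs3)C2=O)nc2ccccc21` is not yet measured in this assay. It differs from compound 1 by methyl in place of hydrogen on a saturated chain carbon bound to an aromatic nitrogen. This is the same kind of change as that from compound 2 to compound 3, though not the same: there the carbon carrying the new methyl is bound to an aromatic nitrogen and a saturated chain carbon, here only to an aromatic nitrogen.

Among the measured compounds shown here, for compound 4 a step of a 1.0-fold higher number from compound 1 to compound 4 (0.01 log units; within the scatter) is expected, that is, little movement, since the one comparable step that the two limits leave unreadable from compound 2 to compound 3 gives no readable size and compound 1 itself is a weak inhibitor at 29200 nM. Compound 4 is accordingly estimated at 30000 nM, expected to lie between 12000 nM and 70000 nM.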

Compound 4, half-maximal inhibitory concentration: > 50000 nM
Compound 4 was reported as a limit; the forecaster's own chance of this, stated with the estimate: 30%; middle value at least 1.6-fold (0.22 log units) away from the limit.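

In this assay, methyl in place of hydrogen on a saturated chain carbon bound to an aromatic nitrogen gives an at least 1.7-fold higher number from compound 1 to compound 4 (0.23 log units; that floor lies within the scatter). Going by these compounds, compound 4 gives > 50000 nM, which is a limit of the assay and not a number, so the true size of this step stays unknown and its floor alone does not establish a real change. The same kind of change on the other core cannot be read, since both of its ends are limits, and so the account has no two sizes to set side by side and cannot say whether the change carries from one core to the other: the limit of > 50000 nM in this assay, at which 3 of the 4 values shown sit.

The compounds shown leave open whether a longer chain such as butyl, or a chain ending in an amine or a carboxylic acid, in place of the ethyl of the 1-ethyl-1H-benzimidazol-2-yl group would give a number in this assay and not a limit. Also open, on these data alone, is how the 1-methyl-1H-benzimidazol-2-yl group would read with the rest of compound 2.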